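A few compounds are considered here, and "the series" means these few. Any claim that something is new, unique, unknown or untested is made for them only; others in the source may bear on it.

Three compounds that share one core were measured in a functional assay on LNCaP cells (Homo sapiens) for antiproliferative activity, read by WST assay, with a stated time of 3 days; a higher number here means a weaker inhibitor, a lower number a stronger inhibitor:
compound 1 `CCC(C)Oc1c(-c2cc(OC)c(OC)c(OC)c2)oc2ccccc2c1=O` gives 9300 nM;
compound 2 `CCN(CC)CCCCOc1c(-c2cc(OC)c(OC)c(OC)c2)oc2ccccc2c1=O` gives 13500 nM;
compound 3 `CCN(CC)CCCCCOc1c(-c2cc(OC)c(OC)c(OC)c2)oc2ccccc2c1=O` gives 10000 nM.

The three numbers sit close together. Compound 2 lies at one end of them, yet the step of a 1.5-fold higher number from compound 1 to compound 2 (0.16 log units; within the scatter) and the step of a 1.4-fold lower number from compound 2 to compound 3 (0.13 log units; within the scatter) both stay within the scatter, so none of the three compounds can be told apart from the others on these numbers. The step of a 1.1-fold higher number from compound 1 to compound 3 (0.03 log units; within the scatter) is likewise within the scatter.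

Compound 4 `CCCCCN(CCCCC)CCCCOc1c(-c2cc(OC)c(OC)c(OC)c2)oc2ccccc2c1=O` has not yet been measured. It differs from compound 2 in one place: dipentylamino in place of diethylamino on a saturated chain carbon, four bonds along the chain from an oxygen on an aromatic ring. Within the data shown here, the nearest measured step is the one from compound 2 to compound 3, where the chain carrying the amine was lengthened and the number stayed within the scatter. The steps from compound 1 to compound 2 and from compound 1 to compound 3, which exchanged the whole group on the oxygen, were also within the scatter. Among the measured compounds shown here, no measured step alters the groups on the nitrogen itself, so the move to dipentylamino is a larger change with no direct anchor among the measured compounds. The expectation for compound 4 in this assay is therefore a step of a 1.1-fold lower number from compound 2 to compound 4 (0.05 log units; within the scatter) that does not clearly leave the scatter. Compound 4 is estimated at 12000 nM, with a range from 4000 nM to 36000 nM.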

Compound 4, half-maximal inhibitory concentration: 9700 nM
Beside the measured number, compound 4's estimate is 1.2-fold (0.09 log units) above it, and the stated range covers the measured number.
By their numbers in this assay, from the lowest: compounds 1, 4, 3 and 2 (each within the scatter of the next).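

In this assay, among these compounds, the step of a 1.4-fold lower number from compound 2 to compound 4 (0.14 log units; within the scatter) is the first measured change to the groups on the nitrogen itself, and it stays within the usual scatter, even though dipentylamino has 11 heavy atoms where diethylamino has 5. The step of a 1.0-fold lower number from compound 3 to compound 4 (0.01 log units; within the scatter) is also within the scatter, so exchanging the groups on the nitrogen and lengthening the chain that carries the amine cannot be told apart here, and the four compounds remain indistinguishable on these numbers. The available evidence offers no explanation for why such different groups give numbers this close.

Still open, from the compounds shown here alone, is whether a piperidine or morpholine in place of dipentylamino, or a carboxylic acid in place of the amine, would give a step beyond the scatter. Also open, going by these compounds, is whether any group on this oxygen of the shared core can separate itself from the others in this assay or whether these numbers stay together whatever the group is.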